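The source may hold more compounds than are shown below. What is called first, only, known or untested is meant among the compounds shown, and "the series" means these compounds.

Within the data shown here, in an assay on CHO cells for displacement of a labelled ligand from histamine receptor H3 (Macaca mulatta), read by scintillation counting, with a stated time of 1 h (a higher number here means a weaker inhibitor, a lower number a stronger inhibitor), compound 2 `CC1CCCN1C1CCN(c2ccc(NC(=O)N3CCCCC3)cc2)C1` gives 6 nM, the lowest of the two numbers so far, while compound 1 `CC(=O)N1CCN(C(=O)Nc2ccc(N3CCC(N4CCCC4C)C3)cc2)CC1` gives 34.1 nM. Among the measured compounds shown here, the one measured step, a 5.7-fold lower number from compound 1 to compound 2 (0.75 log units; beyond the scatter), is modest but beyond the scatter. Compound 3 `CC(=O)N(C)C1CCN(C(=O)Nc2ccc(N3CCC(N4CCCC4C)C3)cc2)C1` carries the change (3-(acetyl(methyl)amino)pyrrolidin-1-yl in place of piperidin-1-yl on a carbonyl carbon). The entering group again holds an acetyl group, as compound 1 does, so a step partly reversing a 5.7-fold lower number from compound 1 to compound 2 (0.75 log units; beyond the scatter) is expected, toward a higher number: a 3.3-fold higher number from compound 2 to compound 3 (0.52 log units; beyond the scatter). Compound 3 is therefore estimated at 20 nM, with a likely range from 8 nM to 60 nM.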

Compound 3, inhibition constant: 35.5 nM
The estimate for compound 3 lay 1.8-fold (0.25 log units) below the measured number, and the stated range covers the measured number.
By their numbers in this assay, from the lowest: compound 2; then compounds 1 and 3 (each within the scatter of the next).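

In this assay, the change gave a 5.9-fold higher number from compound 2 to compound 3 (0.77 log units; beyond the scatter), so a second acetyl-bearing group on this carbonyl carbon also stands apart from piperidin-1-yl. The comparison of the two acetyl-bearing groups gives a 1.0-fold higher number from compound 1 to compound 3 (0.02 log units; within the scatter), which means that 3-(acetyl(methyl)amino)pyrrolidin-1-yl and 4-acetylpiperazin-1-yl cannot be told apart here, despite their different rings. No supporting data bear on why this is so. The compounds shown leave open whether the acetyl group itself accounts for the gap from compound 2. They also leave open where an unsubstituted pyrrolidin-1-yl or a morpholin-4-yl would fall.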